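The source may hold more compounds than are shown below. What is called first, only, known or untested is meant among the compounds shown, and "the series" means these compounds.

Two compounds share a small core and differ only in the group carried on an amide-type nitrogen. Compound 1 `CCCCNC(=O)N1CC1C#N` carries a butyl group there, and in a functional assay on A-375 cells (Homo sapiens) for inhibition (a lower number here means a stronger inhibitor, a higher number a weaker inhibitor), compound 1 gives 15000 nM. Going by the values given here, compound 2 `CC(C)(C)NC(=O)N1CC1C#N` carries a tert-butyl group instead, and in this assay compound 2 gives 418000 nM, the higher of the two numbers; the single step recorded, a 28-fold higher number from compound 1 to compound 2 (1.45 log units; beyond the scatter), is large. Compound 3 `N#CC1CN1C(N)=O` takes the change one stage further: hydrogen in place of tert-butyl on an amide-type nitrogen. Among the compounds with values here, no measured step removes an alkyl group entirely, so the only guide is that swapping butyl for tert-butyl weakened inhibition sharply, which makes the effect of removing the group altogether uncertain in direction. Compound 3 is therefore expected to land somewhere between the two measured numbers, with a 4.2-fold lower number from compound 2 to compound 3 (0.62 log units; beyond the scatter) as the estimated step, giving an estimate of 100000 nM within a wide range from 15000 nM to 700000 nM.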

Compound 3, half-maximal inhibitory concentration: > 90000 nM
Compound 3: only a limit was reported (the forecaster's own chance of this, stated with the estimate: 20%); the middle value lies beyond the limit too.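

For compound 3, this assay gives only a limit and not a number: the limit of > 90000 nM in this assay, at which 1 of the 3 values shown sits. Even so, the comparison with the butyl compound can be read, and hydrogen in place of butyl on the amide-type nitrogen gives an at least 6.0-fold higher number from compound 1 to compound 3 (0.77 log units; beyond the scatter), so losing the butyl group costs inhibition by an amount beyond the scatter, and the true loss may be larger. The step from compound 2 to compound 3 cannot be read, so the compounds do not show whether hydrogen on this nitrogen does better or worse than tert-butyl.

Still open, on these data alone, is whether a longer chain such as hexyl, or a ring such as phenyl, on this nitrogen would give a lower number than butyl does. Equally open, as far as these compounds go, is what a butyl chain carrying an amine or a carboxylic acid would do.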